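The compounds below may be only part of what the source reports. "The series", "measured", "known", "first", "only" and "open" are said of these compounds alone.

Working notes on the tetrazolylthioacetohydrazone series in an ADME assay on NIH3T3 cells (Mus musculus) for cytotoxicity, read by XTT assay, with a stated time of 24 h; a lower number here means a stronger inhibitor, a higher number a weaker inhibitor. Compound 1 `Cn1nnnc1SCC(=O)N/N=C/c1ccc([N+](=O)[O-])cc1` gives 9300000 nM. Compound 2 `Cc1ccc(/C=N/NC(=O)CSc2nnnn2C)cc1` gives 3160000 nM, and compound 3 `Cn1nnnc1SCC(=O)N/N=C/c1ccc(Cl)cc1` gives 2100000 nM. The step of a 2.9-fold lower number from compound 1 to compound 2 (0.47 log units; beyond the scatter) and the step of a 4.4-fold lower number from compound 1 to compound 3 (0.65 log units; beyond the scatter) both run toward lower numbers, whereas the step of a 1.5-fold lower number from compound 2 to compound 3 (0.18 log units; within the scatter) stays within the scatter. Compound 3 therefore sits at the low end of the three, separated from compound 1 beyond the scatter but not separable from compound 2.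

Compound 4 `Cn1nnnc1SCC(=O)N/N=C/c1ccc(C(F)(F)F)cc1` differs from compound 3 by trifluoromethyl in place of chloro on an aromatic carbon. For the measured compounds named here, the only step of a related kind is the exchange a 1.5-fold lower number from compound 2 to compound 3 (0.18 log units; within the scatter), which stayed within the scatter; the steps away from compound 1 were larger but concern the nitro group, which compound 4 does not carry. The exchange from chloro to trifluoromethyl is thus expected to move this assay little, with the step of a 1.1-fold lower number from compound 3 to compound 4 (0.02 log units; within the scatter) estimated as within or near the scatter. Compound 4 is expected to give about 2000000 nM, with a range from 800000 nM to 5000000 nM.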

Compound 4, half-maximal inhibitory concentration: > 10000000 nM
Compound 4 ended at the assay's limit; the forecaster's own chance of this, stated with the estimate: 15%; middle value at least 5.0-fold (0.69 log units) away from the limit.
By their numbers in this assay, from the lowest: compounds 3 and 2 (each within the scatter of the next); then compound 1. At a limit, above all of these: compound 4.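

Trifluoromethyl in place of chloro gives an at least 4.7-fold higher number from compound 3 to compound 4 (0.67 log units; beyond the scatter), and trifluoromethyl in place of methyl gives an at least 3.1-fold higher number from compound 2 to compound 4 (0.50 log units; beyond the scatter), so in this assay this position, para to a large group, responds to a change that leaves the hydrogen-bond donor and acceptor counts unchanged. Compound 4 stands at a limit, and the steps to it are floors only: the limit of > 10000000 nM in this assay, at which 1 of the 4 values shown sits. Trifluoromethyl in place of nitro gives an at least 1.0-fold higher number from compound 1 to compound 4 (0.03 log units; that floor lies within the scatter), so no order of these two compounds can be read from it.

From the compounds shown here alone, whether an amine, a carboxylic acid or a longer chain at this position would give a number within the range of the assay remains open. The groups shown also do not separate the heavy-atom count of trifluoromethyl from its other features.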